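The compounds below may be only part of what the source reports. "The series", "measured", "known", "first", "only" and "open" are said of these compounds alone.

In a functional assay on DU-145 cells (Homo sapiens) for antiproliferative activity, read by MTT assay, with a stated time of 48 h (a lower number here means a stronger inhibitor, a higher number a weaker inhibitor), compound 1 `C/C(=C\CC/C(C)=C/CC[C@@H]1[C@@]2(C)CCC(=O)C(C)(C)[C@H]2CC[C@@]1(C)O)CC/C=C(\C)C(=O)OCc1cn(-c2ccc(F)c(Cl)c2)nn1` gives > 150000 nM, which is a limit of the assay and not a number. A related compound, compound 2 `C#CCOC(=O)/C(C)=C/CC/C(C)=C/CC/C(C)=C/CC[C@@H]1[C@@]2(C)CCC(=O)C(C)(C)[C@H]2CC[C@@]1(C)O`, gives 46100 nM. Compound 3 `COc1ccc(-n2cc(COC(=O)/C(C)=C/CC/C(C)=C/CC/C(C)=C/CC[C@@H]3[C@@]4(C)CCC(=O)C(C)(C)[C@H]4CC[C@@]3(C)O)nn2)cc1` has not yet been measured. It has 4-methoxyphenyl in place of the 3-chloro-4-fluorophenyl of compound 1, on an aromatic nitrogen (4-methoxyphenyl in place of 3-chloro-4-fluorophenyl on an aromatic nitrogen). Within the data shown here, no measured pair shows the effect of this change, so only a modest shift towards stronger inhibition in this assay is expected, and compound 3 may also stop at a limit. The expected step of an at least 1.8-fold lower number from compound 1 to compound 3 (0.27 log units; that floor lies within the scatter) is therefore uncertain. For compound 3, the estimated value is 80000 nM, with an expected range of 30000 nM to 150000 nM.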

Compound 3, half-maximal inhibitory concentration: 135000 nM
Estimate against measurement, compound 3: 1.7-fold (0.23 log units) below; the measured number falls inside the stated range.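

In this assay, putting 4-methoxyphenyl in place of 3-chloro-4-fluorophenyl on the aromatic nitrogen gives an at least 1.1-fold lower number from compound 1 to compound 3 (0.04 log units; that floor lies within the scatter). Among these compounds, this is the first reading of a change at this position, and it shows no clear gain in activity. The true size of the step stays unknown because compound 1 gives only a limit: the limit of > 150000 nM in this assay, at which 1 of the 3 values shown sits.

With only these two groups at this position, the separate roles of the chlorine, the fluorine and the methoxy stay unresolved. Also open, going by these compounds, is how an unsubstituted phenyl ring, or a phenyl ring carrying an amine, would read here.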